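From Sulfonyl to Carbamoyl on a Ring Nitrogen

The compounds below may be only part of what the source reports. "The series", "measured", "known", "first", "only" and "open" are said of these compounds alone.

Of the compounds shown here, two have so far been measured in a functional assay on MDA-MB-231 cells (Homo sapiens) for antiproliferative activity, read by MTT assay, with a stated time of 48 h; a higher number here means a weaker inhibitor, a lower number a stronger inhibitor. Compound 1 `C=CS(=O)(=O)N1CCN(c2ccn3ncc(-c4ccccc4)c3n2)CC1` gives 38300 nM, and compound 2 `CN1CCN(c2ccc(-c3cc4c(N5CCN(S(=O)(=O)N6CCCCC6)CC5)ncnc4s3)cc2)CC1` gives 8130 nM. Compound 2 thus stands at the lowest of the two numbers, with compound 1 as its nearest neighbour, and that gap lies beyond the usual scatter. The two structures differ in several places, so only their values can be set side by side.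

Compound 3 `CN1CCN(c2ccc(-c3cc4c(N5CCN(C(=O)Nc6ccc(F)cc6F)CC5)ncnc4s3)cc2)CC1` has not yet been measured. Among the measured compounds shown here, it differs from compound 2 in one place: (2,4-difluorophenyl)carbamoyl in place of (piperidin-1-yl)sulfonyl on an amine nitrogen in a ring No step between measured compounds shows how such a change acts in this assay, so any expectation rests on compound 2 alone. The step of a 1.6-fold lower number from compound 2 to compound 3 (0.21 log units; within the scatter) is expected to be small, leaning if anything toward a lower number, and not clearly beyond the scatter. The estimate for compound 3 in this assay is 5000 nM, with a range from 1500 nM to 20000 nM.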

Compound 3, half-maximal inhibitory concentration: 11400 nM
Estimate against measurement, compound 3: 2.3-fold (0.36 log units) below; measured number inside the range.
By their numbers in this assay, from the lowest: compounds 2 and 3 (each within the scatter of the next); then compound 1.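

In this assay, the exchange of (piperidin-1-yl)sulfonyl for (2,4-difluorophenyl)carbamoyl on an amine nitrogen in a ring gives a 1.4-fold higher number from compound 2 to compound 3 (0.15 log units; within the scatter). At this position, then, the read-out does not separate the two groups, even though one brings a six-membered non-aromatic ring with a hetero atom and the other a six-membered aromatic ring of carbon only, along with a hydrogen-bond donor. No supporting measurement is available to explain this outcome.

As far as these compounds go, what remains open is whether this tolerance extends to much smaller groups on the same nitrogen, such as an acetyl or a methyl group, or to the unsubstituted ring amine. From the compounds shown here alone, it is also open whether the two fluorine atoms contribute anything, which a plain phenylcarbamoyl group could test.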